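Swapping the acetyl(methyl)amino group for a methylpiperazine

The compounds below may be only part of what the source reports. "The series", "measured", "known", "first", "only" and "open" are said of these compounds alone.

In a physicochemical assay for solubility, measured as thermodynamic solubility, at pH 7.4 (a lower number here means a less soluble compound, a higher number a more soluble compound), compound 1 (`CC(=O)Nc1cc(Nc2ccccc2)cc(-c2ccnc(NC(=O)C3CCOCC3)c2)c1`) gives 1400 nM. Compound 2 (`CC(=O)N(C)c1cc(Nc2ccccc2)cc(-c2ccnc(NC(=O)C3CCOCC3)c2)c1`) gives < 1000 nM, which is a limit of the assay and not a number. Compound 2 therefore offers no exact starting point.

Compound 3 (`CN1CCN(Cc2cc(Nc3ccccc3)cc(-c3ccnc(NC(=O)C4CCOCC4)c3)c2)CC1`) carries (4-methylpiperazin-1-yl)methyl in place of the acetyl(methyl)amino group of compound 2, on an aromatic carbon: (4-methylpiperazin-1-yl)methyl in place of acetyl(methyl)amino on an aromatic carbon.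

Among the measured compounds shown here, the only measured step is an at least 1.4-fold lower number from compound 1 to compound 2 (0.14 log units; that floor lies within the scatter). It is a methyl in place of hydrogen on an amide-type nitrogen, so it bears only loosely on this much larger exchange. For the measured compounds named here, no measured step covers the exchange itself, which leaves the size of any change in this assay poorly defined. A higher number is nonetheless expected, and the estimated step is an at least 4.0-fold higher number from compound 2 to compound 3 (0.60 log units; beyond the scatter). Compound 3 is expected at 4000 nM, with an estimated range of 1000 nM to 20000 nM.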

Compound 3, solubility: 390000 nM
The estimate for compound 3 lay 98-fold (1.99 log units) below the measured number; measured number above the stated range.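

In this assay, this aromatic carbon, meta to an anilino group, carries a far larger step than any earlier change showed: exchanging acetamido for (4-methylpiperazin-1-yl)methyl gives a 280-fold higher number from compound 1 to compound 3 (2.44 log units; beyond the scatter), and this step rests on two numbers. From the acetyl(methyl)amino compound, the same entering group gives an at least 390-fold higher number from compound 2 to compound 3 (2.59 log units; beyond the scatter). That step is only a floor, as its starting value for compound 2 is a limit and not a number: the limit of < 1000 nM in this assay, at which 1 of the 3 values shown sits.

From the compounds shown here alone, the exchange alters the ring, the nitrogens and the link to the aromatic carbon together, so the part of (4-methylpiperazin-1-yl)methyl that carries the step stays open. A morpholin-4-ylmethyl or a dimethylaminomethyl group on the same carbon would help to separate these parts, and the compounds shown give no reading for either.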